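The compounds below may be only part of what the source reports. "The series", "measured", "known", "first", "only" and "open" are said of these compounds alone.

Working notes on the series, read in a functional assay on Sarcoma-180 cells (Mus musculus) for inhibition; on this read-out lower numbers stand for an effect already at smaller amounts and higher numbers for an effect only at larger amounts of compound. Compound 1 (`N[C@@H]1C[C@H](n2cc(F)c(=O)[nH]c2=O)O[C@@H]1CO`) gives 1 uM, the lowest of the three numbers in hand. Compound 2 (`Cc1cn([C@H]2C[C@@H](N)[C@@H](CO)O2)c(=O)nc1N`) gives 20 uM, and compound 3 (`[N-]=[N+]=N[C@H]1C[C@H](n2cc(F)c(=O)[nH]c2=O)O[C@@H]1CO`) gives 40 uM. For the measured compounds named here, both gaps to compound 1 lie beyond the scatter, so compound 1 is the most potent of the three measured so far.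

Compound 4 (`N[C@@H]1C[C@H](n2cc(C(F)(F)F)c(=O)[nH]c2=O)O[C@@H]1CO`) keeps the core of compound 1 and carries a single change: trifluoromethyl in place of fluoro on an aromatic carbon, (trifluoromethyl in place of fluoro on an aromatic carbon). The group sits on an aromatic carbon of a six-membered aromatic ring with 2 nitrogen.

Going by the values given here, no measured pair isolates a change at this place, so the size of the step in this assay has no direct precedent. Among the compounds with values here, the only guide is that compound 1, at 1 uM, sits at the low end of the numbers, and neither other measured compound comes close to it. A move to a higher number is therefore the more likely direction, of moderate size and probably beyond the scatter, though this is weak ground. The expected step is an 8.0-fold higher number from compound 1 to compound 4 (0.90 log units; beyond the scatter). Compound 4 is estimated at 8 uM, with an expected range from 1.5 uM to 40 uM.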

Compound 4, concentration for half-maximal effect: 100 uM
Estimate against measurement, compound 4: 13-fold (1.10 log units) below, and the stated range ends below it.
By their numbers in this assay, from the lowest: compound 1; then compounds 2 and 3 (each within the scatter of the next); then compound 4.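

In this assay, for the compounds shown here, the exchange of fluoro for trifluoromethyl on the aromatic carbon gives a 100-fold higher number from compound 1 to compound 4 (2.00 log units; beyond the scatter) and is the first single-place change that can be read. The earlier compounds shown here showed nothing about this position on its own, whereas this step shows that the number responds strongly to the group placed there. The step is large and beyond the scatter, and with the rest of the core of compound 1 unchanged, it belongs entirely to the move from a group of 1 heavy atom to a group of 4 heavy atoms, although nothing in hand accounts for its size.

With only fluoro and trifluoromethyl read at this aromatic carbon on the shared core, two points cannot fix how the number runs across other groups there, such as chloro, bromo, ethyl or a nitrile. As far as these compounds go, it also remains open whether trifluoromethyl in place of fluoro would carry a step of similar size in the azide-bearing compound 3, or whether the size seen here is particular to the core of compound 1.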